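Fluorine at two places on a shared diaryl ether scaffold

The compounds below may be only part of what the source reports. "The series", "measured", "known", "first", "only" and "open" are said of these compounds alone.

Four compounds share one core, a diaryl ether carrying a methylcarbamoyl-pyridine on one side and an amide-linked pyrimidine on the other. Compound 1 `CNC(=O)c1cc(Oc2ccc(NC(=O)c3cc(-c4ccc(C)cc4)ncn3)cc2)ccn1` has no fluorine. In a functional assay on PC-3 cells (Homo sapiens) for cytotoxicity, read by MTT assay, with a stated time of 72 h (a higher number here means a weaker inhibitor, a lower number a stronger inhibitor), compound 1 reaches only the limit > 100000 nM, a boundary of the measurement rather than a number. Compound 2 `CNC(=O)c1cc(Oc2ccc(NC(=O)c3cc(-c4ccc(C)cc4)ncn3)cc2F)ccn1` carries one more fluorine, the change being (fluoro in place of hydrogen on an aromatic carbon). In this assay compound 2 gives 40200 nM. The step of an at least 2.4-fold lower number from compound 1 to compound 2 (0.39 log units; beyond the scatter) can only be given as a bound, because compound 1 sits at the limit of > 100000 nM in this assay, at which 1 of the 3 values shown sits. Compound 3 `CNC(=O)c1cc(Oc2ccc(NC(=O)c3cc(-c4ccccc4)ncn3)cc2F)ccn1` differs from compound 2 by a 1.1-fold higher number from compound 2 to compound 3 (0.04 log units; within the scatter), and in this assay compound 3 gives 44300 nM. How compound 3 differs from compound 1 is not broken down here.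

Compound 4 `CNC(=O)c1cc(Oc2ccc(NC(=O)c3cc(-c4ccc(F)cc4)ncn3)cc2F)ccn1` is not yet measured. It differs from compound 3 by fluoro in place of hydrogen on an aromatic carbon. Among the compounds with values here, this is the same kind of change as the one from compound 1 to compound 2, but not the same: there the fluorine entered ortho to a (2-(methylcarbamoyl)pyridin-4-yl)oxy group and meta to a large group, whereas here it enters para to a large group on a different ring. Because the earlier exchange of methyl for hydrogen on this ring moved the number only by a 1.1-fold higher number from compound 2 to compound 3 (0.04 log units; within the scatter), the step from compound 3 to compound 4 is expected to be small, about a 1.1-fold lower number from compound 3 to compound 4 (0.04 log units; within the scatter). For compound 4 the estimated value in this assay is 40000 nM, expected to fall between 15000 nM and 100000 nM.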

Compound 4, half-maximal inhibitory concentration: > 100000 nM
Compound 4 ended at the assay's limit; the forecaster's own chance of this, stated with the estimate: 15%; middle value at least 2.5-fold (0.39 log units) away from the limit.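

Compound 4 is given only as a limit in this assay, not as a number: the limit of > 100000 nM in this assay, at which 2 of the 4 values shown sit.

The two steps into compound 4 are therefore bounds as well, an at least 2.2-fold higher number from compound 3 to compound 4 (0.35 log units; beyond the scatter) and, for fluoro in place of methyl, an at least 2.4-fold higher number from compound 2 to compound 4 (0.39 log units; beyond the scatter). Fluoro in place of hydrogen on an aromatic carbon thus gives no single result that can be carried from one core to another in this series, yet the two fluorines stand on different rings, so the comparison shows only that the outcome at one place cannot be assumed at the other, and it gives neither a reason nor the true size of the gap, as compound 1 and compound 4 both end at a limit: the same change on two cores in this assay, an at least 2.4-fold lower number (0.39 log units; beyond the scatter) from compound 1 to compound 2 and an at least 2.2-fold higher number (0.35 log units; beyond the scatter) from compound 3 to compound 4, at least 5.6-fold (0.74 log units) apart, beyond the scatter of two such steps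

The compounds shown leave open whether a 4-fluorophenyl group would give the same result on the core of compound 1, which has no fluorine on the ring of the ether, so the effect of each fluorine alone remains unknown. They also leave open whether a chloro group, a methoxy group or an amine at the same place on the phenyl ring would stay clear of the limit and give a number that can be compared directly.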